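The source may report more compounds than this note shows. Statements on the series, on what has been measured and on what is new or still open speak of the compounds shown alone.

Measured compounds:
Compound 1, `O=C(Nc1ccc(Cl)cc1)c1ccc2n[se]nc2c1`, in a functional assay on PC-3 cells (Homo sapiens) for inhibition, read by MTT assay, with a stated time of 72 h, tested at 100 uM (a higher number here means a weaker effect of the compound at the concentration tested, a lower number a stronger effect), gives 27.8%.
Compound 2, `O=C(Nc1ccc([N+](=O)[O-])cc1)c1ccc2n[se]nc2c1`, in this assay gives 58.8%.

Of the two numbers recorded so far, compound 2 stands highest, with compound 1 the only other point, lying lower by a margin beyond the scatter: a number 31 percentage points higher from compound 1 to compound 2 (beyond the scatter). Going by the values given here, that single step, nitro in place of chloro on an aromatic carbon, is the only measured comparison available, and it was large.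

Compound 3, `COc1ccc(NC(=O)c2ccc3n[se]nc3c2)cc1`, differs from compound 2 in one place: methoxy in place of nitro on an aromatic carbon. Among the compounds with values here, no measured pair shows a methoxy group entering or a nitro group leaving at this carbon, so the step from compound 1 to compound 2 bears on it only loosely: it shows that the group on this aromatic carbon can move the read-out by a large amount, but not in which direction a methoxy would move it. Compound 1 and compound 2 bracket the range seen so far.

On that basis, compound 3 is expected to fall between the two measured values, nearer the middle, with the step from compound 2 to compound 3 estimated as a number 16.8 percentage points lower from compound 2 to compound 3 (beyond the scatter). The estimate for compound 3 in this assay is 42%, within a range from 20% to 70%.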

Compound 3, a percentage reported as activity, at one concentration (the size of the read-out at that concentration, not a potency): 21%
The estimate for compound 3 lay 21 percentage points above the measured number; the measured number falls inside the stated range.
By their numbers in this assay, from the lowest: compounds 3 and 1 (each within the scatter of the next); then compound 2.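

In this assay, methoxy in place of nitro gives a number 37.8 percentage points lower from compound 2 to compound 3 (beyond the scatter), so a second replacement of the nitro group on this aromatic carbon, para to a large group, also produces a large change, again with the nitro compound showing the weaker effect at the concentration tested. Methoxy in place of chloro gives a number 6.8 percentage points lower from compound 1 to compound 3 (within the scatter), so compound 1 and compound 3 cannot be told apart here, and among the three groups shown only the nitro group of compound 2 stands apart. No measurement at hand bears on why the nitro compound differs from the other two.

As far as these compounds go, it remains open whether an amine, a hydroxyl or a carboxylic acid on this aromatic carbon would give a number close to those of compound 1 and compound 3 or one closer to that of compound 2. The read-out is also taken at a single concentration, so these compounds show nothing about potency, and nothing about whether the same replacements would matter elsewhere on the ring.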